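Swapping Two Ring Stereocentres in a Peroxide Acid

The compounds below may be only part of what the source reports. "The series", "measured", "known", "first", "only" and "open" are said of these compounds alone.

Compound 1 `CC(=O)CC/C=C(\C)CCC1=C(C)CCCC1(C)C`: 6340 nM
Compound 2 `C=C1CCCC(C)(C)C1CC[C@]1(C)CC[C@@H]([C@@H](C)C(=O)O)OO1`: > 10000 nM
Compound 3 `C=C1CCCC(C)(C)C1CC[C@]1(C)CC[C@H]([C@@H](C)C(=O)OC)OO1`: 7530 nM

In a functional assay on SW-620 cells (Homo sapiens) for inhibition (a higher number here means a weaker inhibitor of growth, a lower number a stronger inhibitor of growth), compound 1 gives 6340 nM and compound 3 gives 7530 nM. For compound 2 the assay reports only a limit, > 10000 nM, which places it at the weak end of what is shown; that is the limit of > 10000 nM in this assay, at which 1 of the 3 values shown sits. Compound 4 `C=C1CCCC(C)(C)C1CC[C@@]1(C)CC[C@H]([C@@H](C)C(=O)O)OO1` has not been measured yet. Its difference from compound 2 is the two compounds have the same atoms and bonds; at least one stereo element is drawn with a configuration in one of them and without one in the other: 2 of 4 stereo elements differ; a stereocentre at a saturated ring carbon is drawn R in compound 2 and S in compound 4; a stereocentre at a saturated ring carbon is drawn S in compound 2 and R in compound 4. Within the data shown here, no two measured compounds differ in one place only, so no measured step is available. Compound 4 is expected to give about 9000 nM, in the range 3000 nM to 30000 nM. The expected step of an at least 1.1-fold lower number from compound 2 to compound 4 (0.04 log units; that floor lies within the scatter) is judged as no movement beyond the scatter, with a real chance the assay again reports only a limit.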

Compound 4, concentration for 50% growth inhibition: 7230 nM
Beside the measured number, compound 4's estimate is 1.2-fold (0.10 log units) above it; the range from low to high includes it.
By their numbers in this assay, from the lowest: compounds 1, 4 and 3 (each within the scatter of the next). At a limit, above all of these: compound 2.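

In this assay, among these compounds, swapping the two stereocentres at saturated ring carbons gives the first pair here that differs in one place, with an at least 1.3-fold lower number from compound 2 to compound 4 (0.14 log units; that floor lies within the scatter). Compound 2 is reported only as a limit, so the true size of this step cannot be read: the limit of > 10000 nM in this assay, at which 1 of the 4 values shown sits. Compound 4, by contrast, gives a measured number, 7230 nM.

Going by these compounds, whether the ring configuration truly changes growth inhibition stays open while compound 2 has no exact value. Also open, on these data alone, is how the same swap would read with an amide in place of the carboxylic acid.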